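Fluorine Position and a Chlorine Swap on the Benzyl Ring

The source may hold more compounds than are shown below. What is called first, only, known or untested is meant among the compounds shown, and "the series" means these compounds.

Measured compounds:
compound 1 `OC[C@H]1O[C@@H](n2cnc3c(NCc4ccccc4F)ncnc32)[C@H](O)[C@@H]1O`: > 166000 nM
compound 2 `OC[C@H]1O[C@@H](n2cnc3c(NCc4cccc(F)c4)ncnc32)[C@H](O)[C@@H]1O`: > 166000 nM
compound 3 `OC[C@H]1O[C@@H](n2cnc3c(NCc4ccc(F)cc4)ncnc32)[C@H](O)[C@@H]1O`: 13200 nM

In a functional assay on HOS cells (Homo sapiens) for antiproliferative activity, with a stated time of 72 h (on this read-out lower numbers stand for stronger inhibition and higher numbers for weaker inhibition), compound 1 reaches only a limit, > 166000 nM. Compound 2 likewise gives a limit, > 166000 nM. Among the compounds with values here, compound 3 is the single compound with an actual number, 13200 nM. The steps of an at least 12-fold lower number from compound 1 to compound 3 (1.09 log units; beyond the scatter) and an at least 12-fold lower number from compound 2 to compound 3 (1.09 log units; beyond the scatter) both lie beyond the scatter, while a step that the two limits leave unreadable from compound 1 to compound 2 stays unreadable.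

Compound 4 `OC[C@H]1O[C@@H](n2cnc3c(NCc4ccccc4Cl)ncnc32)[C@H](O)[C@@H]1O` differs from compound 3 by 2-chlorophenyl in place of 4-fluorophenyl on a saturated chain carbon bound to a nitrogen on an aromatic ring. Compound 4 thus carries its halogen in the same ring position as compound 1, and an at least 12-fold lower number from compound 1 to compound 3 (1.09 log units; beyond the scatter) is the step that bears on it. The step is expected to run the other way, a 6.1-fold higher number from compound 3 to compound 4 (0.78 log units; beyond the scatter), with a real chance that compound 4 only reaches the limit (the limit of > 166000 nM in this assay, at which 2 of the 3 values shown sit). Compound 4 is estimated at 80000 nM, between 15000 nM and 300000 nM.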

Compound 4, half-maximal inhibitory concentration: > 166000 nM
Compound 4: no number, only a limit; the forecaster's own chance of this, stated with the estimate: 50%; middle value at least 2.0-fold (0.31 log units) from the limit.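

In this assay compound 4 reaches only a limit, > 166000 nM. Placing 2-chlorophenyl in place of 4-fluorophenyl gives an at least 12-fold higher number from compound 3 to compound 4 (1.09 log units; beyond the scatter), so chlorine in this group does not bring back a measurable value. The steps that link compound 4 to compound 1 and compound 2 cannot be read, so chloro in place of fluoro on an aromatic carbon has no readable size: the limit of > 166000 nM in this assay, at which 3 of the 4 values shown sit.

The compounds shown leave open whether an actual number belongs to 4-fluorophenyl alone. From the compounds shown here alone, a bromophenyl or methoxyphenyl group on the same saturated chain carbon remains untested here.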